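The source may hold more compounds than are shown below. What is called first, only, known or untested is meant among the compounds shown, and "the series" means these compounds.

Of the compounds shown here, two have been measured so far in a functional assay on HeLa cells (Homo sapiens) for inhibition, read by MTT assay, with a stated time of 48 h; a higher number here means a weaker inhibitor, a lower number a stronger inhibitor. Compound 1 `O=C1Nc2ccc(F)cc2/C1=C\c1cccc(OCc2cn(Cc3ccccc3)nn2)c1` returns only a limit of the assay: in this assay compound 1 gives > 50000 nM. Compound 2 `CC(=O)c1ccc2c(c1)/C(=C/c1cccc(OCc3cn(Cc4ccccc4)nn3)c1)C(=O)N2` likewise returns only a limit: in this assay compound 2 gives > 50000 nM. For the measured compounds named here, compound 2 therefore stands at the edge of what the assay can report, and every value so far sits there, as the limit of > 50000 nM in this assay, at which 2 of the 2 values shown sit, records. The next compound, compound 3 `CC(=O)c1ccc2c(c1)/C(=C\c1cccc(OCc3cn(Cc4ccccc4)nn3)c1)C(=O)N2`, differs from compound 2 only in drawn geometry the two compounds have the same atoms and bonds and differ only in configuration as drawn: 1 of 1 stereo elements differ; a double bond is drawn Z in compound 2 and E in compound 3: the two compounds have the same atoms and bonds and differ only in configuration as drawn, a double bond drawn Z in compound 2 and E in compound 3. Going by the values given here, no measured pair shows how such a flip plays out here, so no step beyond the usual scatter is expected, and the estimated step of a number no higher from compound 2 to compound 3 (the limit leaves the size open) is expected to stay close to zero. Compound 3 is expected to give about 50000 nM in this assay, within 20000 nM to 200000 nM, most likely again only as a limit.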

Compound 3, half-maximal inhibitory concentration: > 50000 nM
Compound 3: no number, only a limit (the forecaster's own chance of this, stated with the estimate: 85%); the middle value sits exactly at the limit.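

Compound 3 returns only a limit, so the steps from compound 1 and from compound 2 to compound 3 cannot be read: the limit of > 50000 nM in this assay, at which 3 of the 3 values shown sit. The compounds shown leave open whether double-bond geometry, or acetyl in place of fluoro, changes inhibition in this assay at all.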